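The compounds below may be only part of what the source reports. "The series", "measured", "known", "first", "only" and "open" are said of these compounds alone.

Compound 1, `CN(C)S(=O)(=O)c1ccc(NC(=O)C(C)(O)C(F)(F)F)cc1`: 480 nM
Compound 2, `CC(O)(C(=O)Nc1ccc(S(N)(=O)=O)cc1)C(F)(F)F`: 12800 nM
Compound 3, `CCN(CC)S(=O)(=O)c1ccc(NC(=O)C(C)(O)C(F)(F)F)cc1`: 810 nM

All three compounds were measured in an assay on a protein complex (Cavia porcellus) with sulfonylurea receptors; K-ATP channels (Homo sapiens) as the target (on this read-out higher numbers stand for weaker inhibition and lower numbers for stronger inhibition), and share one core, differing only in the group on the sulfonyl sulfur. Compound 3 gives the second highest of the three numbers; its nearest neighbour is compound 1, with a 1.7-fold higher number from compound 1 to compound 3 (0.23 log units; within the scatter), and its furthest is compound 2, with a 16-fold lower number from compound 2 to compound 3 (1.20 log units; beyond the scatter). Compound 4, `CC(O)(C(=O)Nc1ccc(Sc2ccccc2)cc1)C(F)(F)F`, differs from compound 3 in one place: phenylsulfanyl in place of diethylsulfamoyl on an aromatic carbon. The steps seen so far all swap one group for another on the sulfonyl sulfur: a 27-fold higher number from compound 1 to compound 2 (1.43 log units; beyond the scatter) and a 16-fold lower number from compound 2 to compound 3 (1.20 log units; beyond the scatter) are large, while a 1.7-fold higher number from compound 1 to compound 3 (0.23 log units; within the scatter) is within the scatter. None of them removes the sulfonyl sulfur itself, as the step to compound 4 does, so they bear only loosely on it; they show that dimethylamino and diethylamino give similar numbers and amino a far higher one. Within the data shown here, with no closer precedent, compound 4 is expected to land near compound 3 or somewhat higher, estimated at 1500 nM (range 300 nM to 8000 nM), which means a 1.9-fold higher number from compound 3 to compound 4 (0.27 log units; within the scatter).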

Compound 4, half-maximal inhibitory concentration: > 30000 nM
Compound 4 ended at the assay's limit; the forecaster's own chance of this, stated with the estimate: 5%; middle value at least 20-fold (1.30 log units) from the limit.
By their numbers in this assay, from the lowest: compounds 1 and 3 (each within the scatter of the next); then compound 2. At a limit, above all of these: compound 4.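

Swapping the whole diethylsulfamoyl group on the aromatic carbon for phenylsulfanyl, and so losing the sulfonyl group, costs far more than the earlier swaps on the sulfonyl sulfur: in this assay the change gives an at least 37-fold higher number from compound 3 to compound 4 (1.56 log units; beyond the scatter) and an at least 62-fold higher number from compound 1 to compound 4 (1.79 log units; beyond the scatter) in the same direction. Even the plain sulfamoyl group of compound 2, the highest number among the earlier three, does better than phenylsulfanyl, with an at least 2.3-fold higher number from compound 2 to compound 4 (0.36 log units; beyond the scatter) as the step. Compound 4 therefore stands at a limit of the assay, not at a number: the limit of > 30000 nM in this assay, at which 1 of the 4 values shown sits.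

The change both removes the sulfonyl group and brings in a phenyl ring, so these compounds cannot say which of the two matters. Going by these compounds, a phenylsulfonyl group, which holds both the sulfonyl group and the phenyl ring, would separate them, and how far compound 4 lies past its limit stays unknown.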